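The source may hold more compounds than are shown below. What is called first, only, known or untested is meant among the compounds shown, and "the series" means these compounds.

Measured in a functional assay on A549 cells (Homo sapiens) for cytotoxicity, read by MTT assay, with a stated time of 72 h; a lower number here means a stronger inhibitor, a higher number a weaker inhibitor:
- compound 1 `CN(C)CCn1cnnc1-c1cc(Oc2ccc(NC(=O)N/N=C/c3ccc(O)c(Br)c3)cc2F)ccn1`: 1370 nM
- compound 2 `CN(C)CCn1cnnc1-c1cc(Oc2ccc(NC(=O)N/N=C/c3cccc(Cl)c3Cl)cc2F)ccn1`: 1090 nM
- compound 3 `CN(C)CCn1cnnc1-c1cc(Oc2ccc(NC(=O)N/N=C/c3ccc(O)c(F)c3)cc2F)ccn1`: 13400 nM

Compound 3 stands highest of the three numbers; its nearest neighbour is compound 1, with a 9.8-fold higher number from compound 1 to compound 3 (0.99 log units; beyond the scatter), and the furthest is compound 2, with a 12-fold higher number from compound 2 to compound 3 (1.09 log units; beyond the scatter).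

Compound 4 `Cc1cc(/C=N/NC(=O)Nc2ccc(Oc3ccnc(-c4nncn4CCN(C)C)c3)c(F)c2)cc(C)c1O` is not yet measured. The change from compound 3 is 4-hydroxy-3,5-dimethylphenyl in place of 3-fluoro-4-hydroxyphenyl on a carbon with a double bond to nitrogen. Among the measured compounds shown here, two measured steps bear on it: a 9.8-fold higher number from compound 1 to compound 3 (0.99 log units; beyond the scatter) and a 12-fold higher number from compound 2 to compound 3 (1.09 log units; beyond the scatter), both ending at compound 3 and both beyond the scatter. Every replacement of the 3-fluoro-4-hydroxyphenyl seen so far has carried a lower number, so a step downward of roughly that size is expected here, a 6.7-fold lower number from compound 3 to compound 4 (0.83 log units; beyond the scatter). Compound 4 is therefore estimated at 2000 nM, with a range from 700 nM to 8000 nM.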

Compound 4, half-maximal inhibitory concentration: 1640 nM
Estimate against measurement, compound 4: 1.2-fold (0.09 log units) above, within the range that was stated.
By their numbers in this assay, from the lowest: compounds 2, 1 and 4 (each within the scatter of the next); then compound 3.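

In this assay, a phenyl group with no halogen at this position, 4-hydroxy-3,5-dimethylphenyl, recovers most of the loss seen with 3-fluoro-4-hydroxyphenyl (an 8.2-fold lower number from compound 3 to compound 4 (0.91 log units; beyond the scatter)). It also matches the halogen-bearing groups (a 1.5-fold higher number from compound 2 to compound 4 (0.18 log units; within the scatter); a 1.2-fold higher number from compound 1 to compound 4 (0.08 log units; within the scatter)), so among these compounds a halogen is not needed for the lower numbers, and compound 3 alone stands apart. No measurement available here explains this result.

Still open, going by these compounds, is how an amine or a carboxylic acid on this phenyl ring, in place of the hydroxy, would compare.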